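The compounds below may be only part of what the source reports. "The series", "measured", "known", "first", "only" and "open" are said of these compounds alone.

Measured compounds:
Compound 1, `Cc1ccc(C(=O)/C=C/c2ccc3c(c2)B(O)OC3)cc1` — in an ADME assay on L929 cells (Mus musculus) for cytotoxicity, read by resazurin assay, with a stated time of 72 h (on this read-out higher numbers stand for weaker inhibition and lower numbers for stronger inhibition), compound 1 gives > 10 ug/mL, which is a limit of the assay and not a number.
Compound 2, `O=C(/C=C/c1ccc2c(c1)B(O)OC2)c1cccc(F)c1` — compound 2 gives > 10 ug/mL, again a limit.
Compound 3, `O=C(/C=C/c1ccc2c(c1)B(O)OC2)c1ccccc1O` — compound 3 gives > 10 ug/mL, also a limit.

Compound 1 therefore stands at a limit only; no number places it within the set. The steps between the measured compounds are unreadable: a step that the two limits leave unreadable from compound 1 to compound 2, a step that the two limits leave unreadable from compound 1 to compound 3 and a step that the two limits leave unreadable from compound 2 to compound 3 all lack a readable size because every value shown sits at the limit of > 10 ug/mL in this assay, at which 3 of the 3 values shown sit. The unmeasured compound 4, `COc1ccc(C(=O)/C=C/c2ccc3c(c2)B(O)OC3)cc1`, differs from compound 1 by methoxy in place of methyl on an aromatic carbon. Among the compounds with values here, none of the measured steps concerns a methoxy for methyl exchange, and none has a readable size, so nothing here points to a step in either direction; the only guidance is that three changes of the aryl group on the carbonyl carbon left every value at the same limit. Compound 4 is therefore expected to show no step beyond the scatter, a step that the limit leaves unreadable from compound 1 to compound 4, and most likely a limit again. The estimate for compound 4 is 30 ug/mL, with a range from 10 ug/mL to 100 ug/mL.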

Compound 4, half-maximal inhibitory concentration: > 10 ug/mL
Compound 4 ended at the assay's limit; the forecaster's own chance of this, stated with the estimate: 85%; the middle value is on the limit's open side.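

No step can be read between compound 1 and compound 4, because both values are limits and not numbers: the limit of > 10 ug/mL in this assay, at which 4 of the 4 values shown sit.

The compounds shown leave open where each one truly lies past that limit, and whether any of these exchanges shifts the read-out in this assay at all.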